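Ester, amide and acid variants on a shared core

The source may hold more compounds than are shown below. What is called first, only, known or untested is meant among the compounds shown, and "the series" means these compounds.

Measured compounds:
- compound 1 `CCOC(=O)c1c(C)oc2ncnc(Nc3cccc(C)c3)c12` — > 1000000 nM
- compound 2 `Cc1oc2ncnc(Nc3cccc(Br)c3)c2c1C(=O)O` — 43000 nM
- compound 3 `CCCNC(=O)c1c(C)oc2ncnc(Nc3cccc(C)c3)c12` — > 1000000 nM

In a functional assay on A549 cells (Homo sapiens) for cytotoxicity, read by MTT assay, with a stated time of 72 h (a higher number here means a weaker inhibitor, a lower number a stronger inhibitor), compound 1 gives only a limit, > 1000000 nM. Compound 3 likewise gives only a limit, > 1000000 nM. Compound 2 gives a number in this assay, 43000 nM. Compound 3 thus stands at the limit of > 1000000 nM in this assay, at which 2 of the 3 values shown sit, and cannot be placed against the others. Compound 4 `Cc1cccc(Nc2ncnc3oc(C)c(C(=O)O)c23)c1` carries the change (hydroxy in place of propylamino on a carbonyl carbon). Going by the values given here, the one measured step, a step that the two limits leave unreadable from compound 1 to compound 3, is unreadable and gives no guide to size or direction. Among the compounds with values here, the only number in the set comes from compound 2, the other carboxylic acid, at 43000 nM. Compound 4 is therefore expected at 100000 nM (range 20000 nM to 600000 nM), an expected step of an at least 10-fold lower number from compound 3 to compound 4 (1.00 log units; beyond the scatter) whose size cannot be read against a limit.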

Compound 4, half-maximal inhibitory concentration: 100000 nM
Compound 4: middle estimate and measured number agree at the digits printed; the range from low to high includes it.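

In this assay, propylcarbamoyl to carboxy brings an at least 10-fold lower number from compound 3 to compound 4 (1.00 log units; beyond the scatter), and hydrogen in place of ethyl on an oxygen next to a carbonyl group brings an at least 10-fold lower number from compound 1 to compound 4 (1.00 log units; beyond the scatter). Between the two acids, methyl in place of bromo on an aromatic carbon brings a 2.3-fold higher number from compound 2 to compound 4 (0.37 log units; beyond the scatter), so a number is reached with either group on the acid. Compounds 1 and 3 remain limits, not numbers: the limit of > 1000000 nM in this assay, at which 2 of the 4 values shown sit.

As far as these compounds go, the true size of the steps from those limits stays open. Also open, from the compounds shown here alone, is what a primary carboxamide or a hydroxamic acid on this carbonyl carbon would give.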